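Hexyl chain versus dimethylaminoethyl chain: liver microsome stability

The source may hold more compounds than are shown below. What is called first, only, known or untested is meant among the compounds shown, and "the series" means these compounds.

Measured so far:
compound 1 `CN/C(=N\C1=NC(=O)C(=O)N1C(C)C)Nc1ccc(Cl)c(Cl)c1` — > 1 h
compound 2 `CCCCCCN/C(=N\C1=NC(=O)C(=O)N1C(C)C)Nc1ccc(Cl)c(Cl)c1` — 0.131 h

In an in vitro ADME assay on microsomes from liver (Homo sapiens) for metabolic stability, read by LC-MS (a lower number here means that the compound disappears faster, a higher number that the compound lasts longer), compound 1 reaches only a limit, > 1 h. For the measured compounds named here, compound 2 gives the sole actual number in this assay, 0.131 h. Going by the values given here, the step of an at least 7.6-fold lower number from compound 1 to compound 2 (0.88 log units; beyond the scatter) is the one measured step. Compound 3 `CC(C)N1C(=O)C(=O)N=C1/N=C(\NCCN(C)C)Nc1ccc(Cl)c(Cl)c1` is not yet measured; it differs from compound 2 by dimethylamino in place of butyl on a saturated chain carbon, two bonds along the chain from an amine nitrogen. Among the compounds with values here, the measured step concerns adding pentyl to the amine-bound chain carbon and lowered the number; the change to compound 3 shortens that chain and adds an acceptor, so a higher number is expected, though no measured step covers the dimethylamino itself. The step of a 3.8-fold higher number from compound 2 to compound 3 (0.58 log units; beyond the scatter) is the estimate. Compound 3 is expected near 0.5 h, between 0.15 h and 1.5 h.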

Compound 3, half-life: > 1 h
Compound 3: only a limit was reported (the forecaster's own chance of this, stated with the estimate: 25%); middle value at least 2.0-fold (0.30 log units) away from the limit.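

In this assay, the change from hexyl to 2-(dimethylamino)ethyl gives an at least 7.6-fold higher number from compound 2 to compound 3 (0.88 log units; beyond the scatter), so a chain longer than the methyl of compound 1 need not bring a short half-life. Compound 3 reaches only a limit, > 1 h. The step between compound 1 and compound 3 cannot be read, and the top of the series stays unranked: the limit of > 1 h in this assay, at which 2 of the 3 values shown sit.

Open, on these data alone, is whether the dimethylamino end or the shorter chain carries the step. A butyl chain, or a hexyl chain ending in a hydroxyl, would separate the two.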